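Fluoro for Methoxy on a Shared Amidine Core

This account rests on a few compounds, and the source may have more. Where it says the series, first, only, none or still open, it means among the compounds named here.

Of the compounds shown here, three have been tested in a functional assay on A498 cells (Homo sapiens) for inhibition, read by sulforhodamine B assay, with a stated time of 48 h; on this read-out lower numbers stand for stronger inhibition of growth and higher numbers for weaker inhibition of growth. Compound 1, `COc1ccc(-c2ccc(-c3ccc(C(=N)N)o3)o2)cc1`, gives 1760 nM in this assay. Compound 2, `N=C(N)c1ccc(-c2ccc(-c3cncc4ccccc34)s2)s1`, gives 1690 nM, and compound 3, `COc1cc(OC)cc(-c2ccc(-c3ccc(C(=N)N)o3)o2)c1`, gives 2890 nM. These three numbers lie close to one another: each gap between them falls inside the usual scatter of repeated measurements, so none of the three can be called stronger or weaker than the others on this evidence. Compound 1 therefore sits in the middle of a tight cluster rather than at a clear edge of it.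

Compound 4, `N=C(N)c1ccc(-c2ccc(-c3ccc(F)cc3)o2)o1`, has not yet been measured. It shares the core of compound 1 and differs from it in a single place: fluoro in place of methoxy on an aromatic carbon. Among the measured compounds there is no pair that differs only in this way, so no measured step can guide the expectation directly. Given how closely the three measured compounds agree, the step is expected to be small, with no clear direction, and is estimated as a 1.0-fold higher number from compound 1 to compound 4 (0.01 log units; within the scatter). On that basis compound 4 is expected to give about 1800 nM in this assay, with a likely range from 800 nM to 4000 nM.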

Compound 4, concentration for 50% growth inhibition: 1900 nM
The estimate for compound 4 lay 1.1-fold (0.02 log units) below the measured number; measured number inside the range.
By their numbers in this assay, from the lowest: compounds 2, 1, 4 and 3 (each within the scatter of the next).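

In this assay, going by these compounds alone, the swap of methoxy for fluoro on the aromatic carbon para to a large group gives a 1.1-fold higher number from compound 1 to compound 4 (0.03 log units; within the scatter) and so provides the first direct reading of a single change on this core. That step lies within the scatter, so compound 1 and compound 4 cannot be told apart here, even though methoxy counts 2 heavy atoms and 1 hydrogen-bond acceptor while fluoro counts 1 heavy atom and 0 hydrogen-bond acceptors. Nothing measured alongside these growth numbers bears on why the two compounds cannot be separated.

This is one step at one position on one core, so it does not show whether the same position would accept very different groups, such as an amine, a carboxylic acid or a longer chain such as butoxy, with equally little effect on the number. It also leaves open whether fluoro in place of methoxy would give a similarly small step if made on another core or at another place on this six-membered ring.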